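Nitro for fluoro on the cinnamoyl aryl of compound 3

This account rests on a few compounds, and the source may have more. Where it says the series, first, only, none or still open, it means among the compounds named here.

Compound 3 `COc1ccc(C(=O)c2cc(OC)c(OC)c(OC)c2)cc1NC(=O)/C=C/c1ccc(F)cc1` stands with compound 1 `COc1ccc(C(=O)c2cc(OC)c(OC)c(OC)c2)cc1N` at the low end of the three numbers in a functional assay on HeLa cells (Homo sapiens) for cytotoxicity, read by MTT assay, with a stated time of 72 h; a lower number here means a stronger inhibitor, a higher number a weaker inhibitor: compound 3 gives 60 nM, and compound 1 gives 60 nM. Compound 2 `COc1cccc(/C=C/C(=O)Nc2cc(OC)c(OC)c(OC)c2)c1` lacks the shared core; in this assay compound 2 gives 12300 nM. Among the compounds with values here, the one single-site step measured, no change at the digits printed from compound 1 to compound 3 (within the scatter), shows that the whole (2-(4-fluorophenyl)ethenyl)carbonyl on the ring nitrogen left the number where it was. Compound 4 `COc1ccc(C(=O)c2cc(OC)c(OC)c(OC)c2)cc1NC(=O)/C=C/c1ccc([N+](=O)[O-])cc1` differs from compound 3 by nitro in place of fluoro on an aromatic carbon. Within the data shown here, no measured step touches this position; the only step nearby says the amide arm as a whole is carried without effect. The expected step is therefore about no change at the digits printed from compound 3 to compound 4 (within the scatter), none beyond the scatter. Compound 4 is estimated at 60 nM, with an expected range of 25 nM to 150 nM.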

Compound 4, half-maximal inhibitory concentration: 8500 nM
Estimate against measurement, compound 4: 140-fold (2.15 log units) below; the measured number lies above the stated range.
By their numbers in this assay, from the lowest: compounds 1 and 3 (each within the scatter of the next); then compounds 4 and 2 (each within the scatter of the next).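

In this assay nitro in place of fluoro on this aromatic carbon gives a 140-fold higher number from compound 3 to compound 4 (2.15 log units; beyond the scatter) and so makes this position, unlike the amide arm as a whole, sensitive to substitution. The earlier step, no change at the digits printed from compound 1 to compound 3 (within the scatter), held only for the arm carrying 4-fluorophenyl; with 4-nitrophenyl, the arm no longer leaves the number in place. No measurement here accounts for the size of this step.

Going by these compounds, whether the rise is specific to nitro remains open, as does how an amine, a nitrile or a carboxylic acid on this carbon would read. Hydrogen at this carbon would give the unsubstituted baseline for the arm.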